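This account rests on a few compounds, and the source may have more. Where it says the series, first, only, none or still open, it means among the compounds named here.

Compound 1 `O=C(COc1ccc(Cl)cc1)N1CCN(c2ncnc3sc(F)cc23)CC1` gives 6350 nM in a functional assay on cells (Lymphocyte); on this read-out lower numbers stand for stronger inhibition and higher numbers for weaker inhibition.
Compound 2 `NC(=O)c1nc(N2CCN(C(=O)COc3ccc(Cl)cc3)CC2)c2cc(F)sc2n1` gives only a limit, > 10000 nM, in this assay.

Compound 2 thus stands at the upper bound of this assay: its value is not a number but a limit, and its true position is open. For the measured compounds named here, the single measured step, an at least 1.5-fold higher number from compound 1 to compound 2 (0.19 log units; that floor lies within the scatter), rests on (the limit of > 10000 nM in this assay, at which 1 of the 2 values shown sits), so its real size is unknown beyond a floor that lies within the scatter.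

Compound 3 `Nc1nc(N2CCN(C(=O)COc3ccc(Cl)cc3)CC2)c2cc(F)sc2n1` is not yet measured in this assay. It differs from compound 2 in one place: amino in place of carbamoyl on an aromatic carbon. Going by the values given here, the carbamoyl that was added going from compound 1 to compound 2 is replaced here by an amino, so the only comparison that bears on this change is the step from hydrogen to carbamoyl, and that step was small and uncertain. A step beyond the scatter in either direction is therefore not expected with any confidence. Compound 3 is estimated at 9000 nM in this assay, with a range from 3000 nM to 30000 nM. The expected step is an at least 1.1-fold lower number from compound 2 to compound 3 (0.04 log units; that floor lies within the scatter), which should be read against the limit.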

Compound 3, half-maximal inhibitory concentration: 700 nM
Compound 3: middle estimate off by 13-fold (1.11 log units), on the high side, and the stated range ends above it.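

The carbon between two ring nitrogen atoms is not an indifferent place in this assay: amino there gives a 9.1-fold lower number from compound 1 to compound 3 (0.96 log units; beyond the scatter), whereas carbamoyl at the same place gave only a step whose floor lies within the scatter. The identity of the group matters as well, since exchanging carbamoyl for amino gives an at least 14-fold lower number from compound 2 to compound 3 (1.15 log units; beyond the scatter), even though the two groups have equal counts of hydrogen-bond donors and acceptors. The true size of that exchange remains unknown beyond its floor, because compound 2 is held at a limit of the assay: the limit of > 10000 nM in this assay, at which 1 of the 3 values shown sits.

The compounds shown do not tell whether the lower number depends on the free amino group or would persist with a methylamino, a dimethylamino or a hydroxyl group at this place. They also leave open why amino and carbamoyl part so widely, and whether amino would have the same effect if the chlorophenoxy acetyl group or the fluorine of the shared core were replaced.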